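Methoxy added to the benzylidene ring of compound 2

The source may hold more compounds than are shown below. What is called first, only, known or untested is meant among the compounds shown, and "the series" means these compounds.

In a physicochemical assay for lipophilicity, in phosphate buffer, measured as octanol-water partition (on this read-out lower numbers stand for lower lipophilicity and higher numbers for higher lipophilicity), compound 2 `S=C(N/N=C/c1ccccc1)Nc1nc2ccc(Cl)cc2s1` gives 4.86, the lower of the two numbers measured, while compound 1 `S=C(N/N=C/c1ccccc1Cl)Nc1nc2ccc(Cl)cc2s1` gives 5.46. Compound 3 `COc1ccc(/C=N/NC(=S)Nc2nc3ccc(Cl)cc3s2)cc1` differs from compound 2 by methoxy in place of hydrogen on an aromatic carbon. Among the measured compounds shown here, the only measured step, a number 0.60 log units lower from compound 1 to compound 2 (beyond the scatter), concerns hydrogen in place of chloro and offers no direct guide to a methoxy group, so no step beyond the scatter is expected here. Compound 3 is therefore estimated at 4.85, between 4.5 and 5.2, a step of a number 0.01 log units lower from compound 2 to compound 3 (within the scatter) from compound 2 that is expected to stay within the scatter.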

Compound 3, partition coefficient: 5.16
Estimate against measurement, compound 3: 0.31 log units below, and the stated range covers the measured number.
By their numbers in this assay, from the lowest: compounds 2, 3 and 1 (each within the scatter of the next, the first and the last beyond it).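

In this assay, methoxy in place of hydrogen on an aromatic carbon, para to a large group, gives a number 0.30 log units higher from compound 2 to compound 3 (within the scatter). Putting 4-methoxyphenyl in place of 2-chlorophenyl gives a number 0.30 log units lower from compound 1 to compound 3 (within the scatter), so compound 3 lies within the scatter of both compound 1 and compound 2, although those two lie beyond the scatter of each other. Nothing available explains these numbers. The compounds shown leave open how an amine or a carboxylic acid on the same aromatic carbon would read in this assay, and whether methoxy elsewhere on this ring would read like compound 3.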